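A few compounds are considered here, and "the series" means these few. Any claim that something is new, unique, unknown or untested is made for them only; others in the source may bear on it.

Compound 2, `COc1cc(Cl)cc(-c2nn(-c3cccc(NC(=O)Nc4ccc(Cl)c(C(F)(F)F)c4)c3)cc2-c2ccncc2)c1`, is the anchor here. In a functional assay on CAKI-1 cells (Homo sapiens) for inhibition, read by sulforhodamine B assay, with a stated time of 48 h, tested at 10 uM (on this read-out higher numbers stand for a weaker effect at the one concentration tested and lower numbers for a stronger effect), compound 2 gives 9.38%, the lowest of the three numbers in hand. Within the data shown here, its closest neighbour is compound 1, `COc1cc(Cl)cc(-c2nn(-c3cccc(NC(=O)Nc4cccc(C(F)(F)F)c4)c3)cc2-c2ccncc2)c1`, for which compound 1 gives 16.1% in this assay; the only single-point step measured, a number 6.7 percentage points lower from compound 1 to compound 2 (within the scatter), is thus small. Far off stands compound 3, `COc1cc(Cl)cc(-c2nn(-c3cccc(NC(=O)c4cc(C(F)(F)F)cc(C(F)(F)F)c4)c3)cc2-c2ccncc2)c1`, where compound 3 gives 68.6% in this assay.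

Compound 4, `COc1cc(Cl)cc(-c2nn(-c3cccc(NC(=O)c4ccc(Cl)c(Cl)c4)c3)cc2-c2ccncc2)c1`, has not yet been tested. It differs from compound 2 by 3,4-dichlorophenyl in place of (4-chloro-3-(trifluoromethyl)phenyl)amino on a carbonyl carbon. Among the measured compounds shown here, no measured step covers this exact exchange, and compound 3 differs from compound 2 in more than one place, so only the two values can be compared: compound 3, which also carries an aryl group directly on the carbonyl carbon rather than an arylamino group, sits far higher than compound 2, beyond the scatter. On that basis compound 4 is expected to move in the same direction, by an estimated a number 45.6 percentage points higher from compound 2 to compound 4 (beyond the scatter) in this assay. The expected value for compound 4 in this assay is therefore 55%, within a range of 25% to 85%.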

Compound 4, a percentage reported as activity, at one concentration (the size of the read-out at that concentration, not a potency): 63.6%
For compound 4 the middle estimate is 8.6 percentage points below the measured one; the measured number falls inside the stated range.
By their numbers in this assay, from the lowest: compounds 2 and 1 (each within the scatter of the next); then compounds 4 and 3 (each within the scatter of the next).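

The exchange on the carbonyl carbon can now be read as a single change in this assay: 3,4-dichlorophenyl in place of (4-chloro-3-(trifluoromethyl)phenyl)amino comes with a number 54.2 percentage points higher from compound 2 to compound 4 (beyond the scatter), and 3,4-dichlorophenyl in place of (3-(trifluoromethyl)phenyl)amino comes with a number 47.5 percentage points higher from compound 1 to compound 4 (beyond the scatter). The shift is thus large from both arylamino compounds, and compound 4 lies within the scatter of compound 3, which carries a different aryl group directly on the carbonyl carbon. Nothing measured here gives a reason for these steps.

The exchange removes the amino link and alters the ring substituents together, so the compounds shown do not separate the two. A (3,4-dichlorophenyl)amino group or a benzyl group on the carbonyl carbon would bear on that question.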